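Ester for amine: compound 4 against its closest neighbour

This account rests on a few compounds, and the source may have more. Where it says the series, first, only, none or still open, it means among the compounds named here.

The three measured compounds share one core and differ only in the group on the saturated chain carbon bound to an aromatic carbon. Compound 1 `Cc1cc(CCC#N)cc(C)c1Oc1cc(Nc2ccc(C#N)cc2)c(N)cc1C(=O)N(C)C` gives 2.86 in a physicochemical assay for lipophilicity, read by HPLC, measured as octanol-water partition, with a stated time of 24 h, at pH 7.4; a lower number here means a more polar compound, a higher number a more lipophilic compound. Compound 2 `Cc1cc(CCC#N)cc(C)c1Oc1cc(Nc2ccc(C#N)cc2)c(N)cc1CN(C)C` gives 2.52, the step being a number 0.34 log units lower from compound 1 to compound 2 (beyond the scatter). Compound 3 `Cc1cc(CCC#N)cc(C)c1Oc1cc(Nc2ccc(C#N)cc2)c(N)cc1CNC1CC1` gives 3.69, which is the highest of the three; the steps to it are a number 0.83 log units higher from compound 1 to compound 3 (beyond the scatter) and a number 1.17 log units higher from compound 2 to compound 3 (beyond the scatter).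

Compound 4 `Cc1cc(CCC#N)cc(C)c1Oc1cc(Nc2ccc(C#N)cc2)c(N)cc1COC(=O)C1CC1` has not yet been measured in this assay. The change from compound 3 is (cyclopropylcarbonyl)oxy in place of cyclopropylamino on a saturated chain carbon bound to an aromatic carbon. Among the compounds with values here, none of the measured steps replaces an amine by an ester, so the nearest guide is how strongly this position moved the numbers: the step from compound 2 to compound 3 was large and the step from compound 1 to compound 3 modest, both upward toward compound 3.

Compound 4 is therefore expected to sit a little higher than compound 3, with an estimated step of a number 0.61 log units higher from compound 3 to compound 4 (beyond the scatter). The estimate for compound 4 in this assay is 4.3, with a range from 3.7 to 4.9.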

Compound 4, partition coefficient: 2.51
Compound 4: the middle estimate sits 1.79 log units above what was measured; the whole stated range lies above it.
By their numbers in this assay, from the lowest: compounds 4 and 2 (each within the scatter of the next); then compound 1; then compound 3.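

Measured in this assay, putting (cyclopropylcarbonyl)oxy in place of cyclopropylamino on a saturated chain carbon bound to an aromatic carbon gives a number 1.18 log units lower from compound 3 to compound 4 (beyond the scatter) even though the three-membered ring of carbon is present on both sides of the change, so the high number of compound 3 does not follow from that ring alone. With a number 0.01 log units lower from compound 2 to compound 4 (within the scatter) nothing separates (cyclopropylcarbonyl)oxy from dimethylamino at this place, although only the first of the two carries that ring. Set against the dimethylcarbamoyl group, a number 0.35 log units lower from compound 1 to compound 4 (beyond the scatter) puts ((cyclopropylcarbonyl)oxy)methyl on the same side as (dimethylamino)methyl, which leaves cyclopropylamino as the only group among these four compounds that lifts the number above that of the dimethylcarbamoyl group.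

The compounds shown leave open where a cyclopropylcarbonylamino group, which keeps the carbonyl and has a nitrogen in place of the oxygen, or a simple cyclopropyloxy ether would fall in this assay relative to compound 3 and compound 4. No measurement is at hand that explains the size of the step between the amine and the ester.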